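A Longer Sulfur-Linked Chain at a Pyrimidine Carbon

A few compounds are considered here, and "the series" means these few. Any claim that something is new, unique, unknown or untested is made for them only; others in the source may bear on it.

Of the compounds shown here, two sharing one core have been measured in a functional assay on the whole organism for activation, with Mus musculus as the target; on this read-out lower numbers stand for an effect already at smaller amounts and higher numbers for an effect only at larger amounts of compound. Compound 1 `Cc1nc(N)c2nc(O)n(Cc3ccccc3)c2n1` carries a methyl group and gives 3 mg/kg. Among the compounds with values here, compound 2 `CCOc1nc(N)c2nc(O)n(Cc3ccccc3)c2n1` carries an ethoxy group in the same place and gives 0.3 mg/kg, the lowest of the two numbers; the only step on record is a 10-fold lower number from compound 1 to compound 2 (1.00 log units; beyond the scatter), a shift beyond the scatter.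

Compound 3 `CCCCSc1nc(N)c2nc(O)n(Cc3ccccc3)c2n1` is not yet measured. It differs from compound 2 in one place, (butylsulfanyl in place of ethoxy on an aromatic carbon), the site being on an aromatic carbon of a six-membered aromatic ring with two nitrogen atoms, between two ring nitrogen atoms, meta to an amino group and to a fused ring.

Within the data shown here, no measured step exchanges ethoxy for butylsulfanyl, so the only guide is the step from compound 1 to compound 2, where a larger group at this position gave a modest drop in dose. On that basis compound 3 is expected to land near compound 2, with the step of no change at the digits printed from compound 2 to compound 3 (within the scatter) within the scatter. The estimate for compound 3 is 0.3 mg/kg, ranging from 0.1 mg/kg to 1 mg/kg.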

Compound 3, minimum effective dose: 0.3 mg/kg
Compound 3: the middle estimate sits on the measured number at the digits printed; the range from low to high includes it.
By their numbers in this assay, from the lowest: compounds 2 and 3 (each within the scatter of the next); then compound 1.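

In this assay, the position tolerates more than the earlier pair could show: replacing ethoxy with the longer butylsulfanyl chain gives no change at the digits printed from compound 2 to compound 3 (within the scatter), so the gain seen with ethoxy is kept when both the chain and its linking atom change. Measured against the small methyl group, the butylsulfanyl chain gives a 10-fold lower number from compound 1 to compound 3 (1.00 log units; beyond the scatter), so two different linked chains at this aromatic carbon now stand apart from methyl by more than the scatter, and neither compound 2 nor compound 3 goes against that small pattern. No supporting evidence bears on what lies behind these numbers.

Since chain length and the linking atom changed together, the compounds shown cannot say what each does alone, or whether the two effects merely offset each other; a butoxy group or an ethylsulfanyl group would separate them. Going by these compounds, it also stays open how far this tolerance extends, for instance to a butylamino group, with a nitrogen as the link, or to a chain longer than butyl.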